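The source may hold more compounds than are shown below. What is called first, only, known or untested is meant among the compounds shown, and "the series" means these compounds.

Two compounds have so far been measured in a physicochemical assay for pharmacokinetics, in phosphate buffer, at pH 7.4; on this read-out lower numbers stand for a shorter-lived compound and higher numbers for a longer-lived compound:

compound 1, `COc1ccc2cc(C(C)C(=O)OCC(OC(C)=O)C(OC(C)=O)C(OC(C)=O)C(/C=N/CC(=O)O)OC(C)=O)ccc2c1`: 25 h
compound 2, `COc1ccc2cc(C(C)C(=O)OCC(OC(C)=O)C(OC(C)=O)C(OC(C)=O)C(/C=N/[C@@H](C)C(=O)O)OC(C)=O)ccc2c1`: 22 h

Compound 2 gives the lower of the two numbers in this assay, but the step of a 1.1-fold lower number from compound 1 to compound 2 (0.06 log units; within the scatter) is within the scatter, so the two values cannot be told apart. That single measured step, methyl in place of hydrogen on a saturated chain carbon bound to a carbonyl carbon and a double-bonded nitrogen, did not carry the number beyond the scatter.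

Compound 3, `COc1ccc2cc(C(C)C(=O)OCC(OC(C)=O)C(OC(C)=O)C(OC(C)=O)C(/C=N/[C@H](C(=O)O)C(C)C)OC(C)=O)ccc2c1`, has not yet been measured in this assay. It differs from compound 2 by isopropyl in place of methyl on a saturated chain carbon bound to a carbonyl carbon and a double-bonded nitrogen; cut one bond further out, the change reads 1-carboxyethyl to 1-carboxy-2-methylpropyl. For the measured compounds named here, the only measured step that bears on this change is the earlier growth at the same place, a 1.1-fold lower number from compound 1 to compound 2 (0.06 log units; within the scatter), which stayed within the scatter. A further enlargement at that place is therefore expected to give no step beyond the scatter in this assay, and the expected step of no change at the digits printed from compound 2 to compound 3 (within the scatter) is small. Compound 3 is expected to give 22 h in this assay, within a range of 13 h to 38 h.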

Compound 3, half-life: 19 h
Beside the measured number, compound 3's estimate is 1.2-fold (0.06 log units) above it, and the stated range covers the measured number.
By their numbers in this assay, from the lowest: compounds 3, 2 and 1 (each within the scatter of the next).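

In this assay, isopropyl in place of methyl on a saturated chain carbon bound to a carbonyl carbon and a double-bonded nitrogen gives a 1.2-fold lower number from compound 2 to compound 3 (0.06 log units; within the scatter), so the second enlargement at this place, like the first, does not carry the half-life beyond the scatter. For the compounds shown here, the earlier compounds offered only one step here, whereas the span from hydrogen to isopropyl can now be read as well, and it gives a 1.3-fold lower number from compound 1 to compound 3 (0.12 log units; within the scatter); even this wider change in the group stays within the scatter, so all three compounds are indistinguishable on this read-out. No measurement at hand accounts for this flat result.

The groups shown at this place are hydrogen, methyl and isopropyl, all without any heteroatom, so it remains open whether an amine, a hydroxyl, a second carboxylic acid or a longer chain there would move the half-life beyond the scatter. All three compounds also share the same core, which leaves open whether the same change would read the same way on a different one.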